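The source may report more compounds than this note shows. Statements on the series, on what has been measured and on what is new or still open speak of the compounds shown alone.

Compound 1 `CCc1ccc2[nH]c(=O)c(CN(Cc3ccc(F)cc3)Cc3ccc(-c4ccccc4)cc3)cc2c1`: > 5000 nM
Compound 2 `Cc1ccc2[nH]c(=O)c(CN(Cc3ccc(OC(F)(F)F)cc3)Cc3ccc(C(C)(C)C)cc3)cc2c1`: > 5000 nM
Compound 3 `CCc1ccc2[nH]c(=O)c(CN(Cc3ccc(C(C)(C)C)cc3)[C@H](C)c3ccc(F)cc3)cc2c1`: > 5000 nM

All three were examined in a toxicity assay on MDCK cells (Canis lupus familiaris) for cytotoxicity, read by crystal violet staining, with a stated time of 48 h; a lower number here means that less compound is tolerated, a higher number that more compound is tolerated. For compound 1 the value > 5000 nM is a limit of the assay, not a number. For compound 2 the value > 5000 nM is likewise only a limit. For compound 3 the value > 5000 nM is a limit as well. Compound 2 therefore stands at the same boundary as the other two, and no step between any pair of these compounds can be measured from what is shown; the one point of evidence is the limit of > 5000 nM in this assay, at which 3 of the 3 values shown sit.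

The unmeasured compound 4 `Cc1ccc2[nH]c(=O)c(CN(Cc3ccc(C(C)(C)C)cc3)C(C)c3ccc(N(C)C)c(Cl)c3)cc2c1` departs from compound 2 by one change: 1-(3-chloro-4-(dimethylamino)phenyl)ethyl in place of 4-(trifluoromethoxy)benzyl on an amine nitrogen. With every measured value sitting at the limit, there is no ground to expect a step in this assay that would exceed the scatter in either direction. Compound 4 is accordingly expected to give about 5000 nM, within 2500 nM to 10000 nM, and the expected step of a number no higher from compound 2 to compound 4 (the limit leaves the size open) is essentially none, with a good chance that only a limit is reported again.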

Compound 4, half-maximal cytotoxic concentration: 9800 nM
The estimate for compound 4 lay 2.0-fold (0.29 log units) below the measured number, within the range that was stated.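

In this assay compound 2 gives > 5000 nM, which is a limit and not a number. Within the data shown here, no step from compound 2 to compound 4 can therefore be read. The compounds shown leave open whether any change on an amine nitrogen moves the half-maximal cytotoxic concentration beyond the usual scatter.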